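Shortening the Acid Chain in a Methylated Analogue

This account rests on a few compounds, and the source may have more. Where it says the series, first, only, none or still open, it means among the compounds named here.

Compound 2 `CN(c1cnccc1SCCCCC(=O)O)c1ccc(C#N)c2ccccc12` gives 3580 nM in an assay on HEK293 cells for inhibition of solute carrier family 22 member 12 (Homo sapiens), read by scintillation counting, with stated times of 30 min and 15 min; on this read-out higher numbers stand for weaker inhibition and lower numbers for stronger inhibition. Its companions on the same read-out are compound 3 `N#Cc1ccc(Nc2cnccc2SCCCCCC(=O)O)c2ccccc12` at 4240 nM and compound 1 `N#Cc1ccc(Nc2cnccc2SCCCC(=O)O)c2ccccc12` at 2780 nM, and both values lie within the scatter of compound 2, so none of the three can be set apart from the others. Compound 4 `CN(c1cnccc1SCCCC(=O)O)c1ccc(C#N)c2ccccc12` differs from compound 2 by carboxy in place of carboxymethyl on a saturated chain carbon, three bonds along the chain from a sulfur. For the measured compounds named here, the only measured step touching chain length is a 1.5-fold higher number from compound 1 to compound 3 (0.18 log units; within the scatter), a move that stayed within the scatter. A single shortening in the methylated series is therefore expected to produce no step beyond the scatter in this assay. The expected step is a 1.1-fold lower number from compound 2 to compound 4 (0.05 log units; within the scatter). Compound 4 is thus estimated at 3200 nM, within a range of 1500 nM to 6500 nM.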

Compound 4, half-maximal inhibitory concentration: 2580 nM
Beside the measured number, compound 4's estimate is 1.2-fold (0.09 log units) above it, and the stated range covers the measured number.
By their numbers in this assay, from the lowest: compounds 4, 1, 2 and 3 (each within the scatter of the next).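

In this assay carboxy in place of carboxymethyl on a saturated chain carbon, three bonds along the chain from a sulfur, gives a 1.4-fold lower number from compound 2 to compound 4 (0.14 log units; within the scatter) in the series with methyl on the nitrogen, so this shortening makes no readable difference there. Methyl in place of hydrogen on a nitrogen on an aromatic ring, a change no earlier pair isolated, gives a 1.1-fold lower number from compound 1 to compound 4 (0.03 log units; within the scatter) and is equally small. No supporting evidence bears on these results.

The compounds shown leave open whether an amine in place of the carboxylic acid, or ethyl in place of methyl on that nitrogen, would stay within the scatter.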